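Replacing the Nitro Group of Compound 2 with Amino

This account rests on a few compounds, and the source may have more. Where it says the series, first, only, none or still open, it means among the compounds named here.

In a functional assay on MC-38 cells (Mus musculus) for antiproliferative activity, read by colorimetric assay and MTT assay (on this read-out higher numbers stand for weaker inhibition and lower numbers for stronger inhibition), compound 2 (`O=[N+]([O-])c1ccc(S(=O)(=O)Nc2cccc3cc(Cl)[nH]c23)cc1`) gives 19 ug/mL. Within the data shown here, this is the middle of the three numbers measured so far, with compound 1 (`O=[N+]([O-])c1ccc(S(=O)(=O)Nc2cccc3cc[nH]c23)cc1`) at 7.2 ug/mL and compound 3 (`O=[N+]([O-])c1ccc(S(=O)(=O)Nc2cccc3cc(O)[nH]c23)cc1`) at 62 ug/mL. Compound 4 (`Nc1ccc(S(=O)(=O)Nc2cccc3cc(Cl)[nH]c23)cc1`) carries amino in place of nitro on an aromatic carbon, para to a large group: amino in place of nitro on an aromatic carbon.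

Among the measured compounds shown here, no measured step makes this change. All three compounds keep the nitro group and differ at another aromatic carbon. Chloro in place of hydrogen gave a 2.6-fold higher number from compound 1 to compound 2 (0.42 log units; beyond the scatter), hydroxy in place of chloro gave a 3.3-fold higher number from compound 2 to compound 3 (0.51 log units; beyond the scatter), and hydroxy in place of hydrogen gave an 8.6-fold higher number from compound 1 to compound 3 (0.94 log units; beyond the scatter). These steps offer only a rough guide to size and leave the direction open, so a modest step of either sign is expected in this assay. The central expectation is a 1.4-fold lower number from compound 2 to compound 4 (0.13 log units; within the scatter). For compound 4 the estimated value is 14 ug/mL, with an expected range of 4 ug/mL to 50 ug/mL.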

Compound 4, half-maximal inhibitory concentration: 2.9 ug/mL
The estimate for compound 4 lay 4.8-fold (0.68 log units) above the measured number; the measured number lies below the stated range.
By their numbers in this assay, from the lowest: compound 4; then compound 1; then compound 2; then compound 3.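

In this assay, among these compounds, the earlier compounds all kept the nitro group and varied only at another aromatic carbon, so this result is the first reading of what a change at this place does: a 6.6-fold lower number from compound 2 to compound 4 (0.82 log units; beyond the scatter). With the chloro group held fixed, this aromatic carbon, para to a large group, clearly responds, and nitro, with 3 heavy atoms and 0 hydrogen-bond donors, gives way to amino, with 1 heavy atom and 1 hydrogen-bond donor, in the direction of stronger inhibition. Nothing measured here accounts for the size or direction of this step.

As far as these compounds go, whether amino would move the number the same way on compound 1 or compound 3 remains open. So does how a methylamino group, an acetamide or a carboxylic acid would compare with amino at this place.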